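Cytotoxicity on HEp-2 Cells: From Sulfonamide to Ester

The source may hold more compounds than are shown below. What is called first, only, known or untested is meant among the compounds shown, and "the series" means these compounds.

Measured compounds:
compound 1 `CC(C)CCn1c(Cn2c(=O)n(C(C)C)c3ccccc32)nc2cc(CNS(C)(=O)=O)ccc21` — 30800 nM
compound 2 `COC(=O)c1cccc2c1nc(Cn1c(=O)n(C(C)C)c3ccccc31)n2CCC(C)C` — 49200 nM

Of the compounds shown here, two have been tested in an ADME assay on HEp-2 cells (Homo sapiens) for cytotoxicity; on this read-out lower numbers stand for higher toxicity in this test and higher numbers for lower toxicity in this test. Compound 1 `CC(C)CCn1c(Cn2c(=O)n(C(C)C)c3ccccc32)nc2cc(CNS(C)(=O)=O)ccc21` gives 30800 nM. Compound 2 `COC(=O)c1cccc2c1nc(Cn1c(=O)n(C(C)C)c3ccccc31)n2CCC(C)C` gives 49200 nM in this assay. On these two numbers compound 1 sits at one end of the pair, yet the gap to compound 2 lies within the usual scatter, so the two cannot be told apart by this test.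

Compound 3 `COC(=O)c1ccc2c(c1)nc(Cn1c(=O)n(C(C)C)c3ccccc31)n2CCC(C)C` has not yet been measured. It differs from compound 1 in one place: methoxycarbonyl in place of (methanesulfonamido)methyl on an aromatic carbon. Compound 2 carries the same methoxycarbonyl group, on a different aromatic carbon of the same ring, and its number is close to that of compound 1. No measured pair here shows the effect of this particular swap, so no cause can be read from the data.

The step of a 1.3-fold higher number from compound 1 to compound 3 (0.11 log units; within the scatter) is expected to be small, no larger than the scatter, and if anything toward a higher number. Compound 3 is estimated at 40000 nM, with a range from 15000 nM to 100000 nM.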

Compound 3, half-maximal cytotoxic concentration: 33700 nM
The estimate for compound 3 lay 1.2-fold (0.07 log units) above the measured number; measured number inside the range.
By their numbers in this assay, from the lowest: compounds 1, 3 and 2 (each within the scatter of the next).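

In this assay, going by these compounds alone, placing methoxycarbonyl instead of (methanesulfonamido)methyl on this aromatic carbon, meta to a fused ring and para to a fused ring, gives a 1.1-fold higher number from compound 1 to compound 3 (0.04 log units; within the scatter), the first direct reading of this swap at this position. The two groups are not alike in what is counted: the group that leaves has 6 heavy atoms, including sulfur and nitrogen, and 1 hydrogen-bond donor, while the group that enters has 4 heavy atoms and 0 hydrogen-bond donors, yet this test cannot tell compound 1 and compound 3 apart. No separate measurement is available here to explain this result.

The compounds shown leave open whether a quite different group on this same aromatic carbon, such as a carboxylic acid, a primary amine or a longer chain ending in an amide, would also stay within the scatter of compound 1. They also leave open whether the same swap would give a step this small if the chain or the isopropyl group elsewhere on the shared core were replaced.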